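The source may report more compounds than this note shows. Statements on the series, on what has been measured and on what is new or still open speak of the compounds shown alone.

Compound 1 `Fc1ccc2c(-c3ccc4ccccc4n3)c[nH]c2c1F` carries a quinoline attached to an indole-type core that bears two fluoro groups. In an ADME assay on microsomes from liver (Homo sapiens) for metabolic stability, using NADPH, with a stated time of 40 min, tested at 2 uM (a lower number here means that the compound disappears faster, a higher number that the compound lasts longer), compound 1 gives 0.167 h. Compound 2 `Fc1cc2c(-c3ccc4ccccc4n3)c[nH]c2c(F)c1F`, with one more fluoro group, gives 0.25 h in this assay. Among the two numbers compound 1 stands lowest, yet the step of a 1.5-fold higher number from compound 1 to compound 2 (0.18 log units; within the scatter) lies within the scatter, so the two cannot be ordered.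

Compound 3 `Cc1ccc2c(-c3ccc4ccccc4n3)c[nH]c2c1F` differs from compound 1 in one place: methyl in place of fluoro on an aromatic carbon. Among the compounds with values here, the only measured step, a 1.5-fold higher number from compound 1 to compound 2 (0.18 log units; within the scatter), concerns fluoro in place of hydrogen at a different spot and bears on the present change only loosely; it showed no movement beyond the scatter. Within the data shown here, no measured pair shows methyl in place of fluoro, so the direction remains open. The number for compound 3 is therefore expected to stay close to that of compound 1, with an expected step of a 1.1-fold lower number from compound 1 to compound 3 (0.05 log units; within the scatter). Compound 3 is estimated at 0.15 h, in a range from 0.07 h to 0.33 h.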

Compound 3, half-life: 0.25 h
For compound 3 the middle estimate is 1.7-fold (0.22 log units) below the measured one, and the stated range covers the measured number.
By their numbers in this assay, from the lowest: compounds 1, 2 and 3 (each within the scatter of the next).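

In this assay, methyl in place of fluoro on this aromatic carbon, which sits ortho to a fluoro group, meta to a fused ring and para to a fused ring, gives a 1.5-fold higher number from compound 1 to compound 3 (0.18 log units; within the scatter), so compound 1 and compound 3 cannot be ordered. Within the data shown here, this is the first measured swap at this carbon, and fluoro and methyl, each a single heavy atom with no hydrogen-bond donors or acceptors, are not told apart here by the half-life. Nothing measured here gives a reason for this result.

As far as these compounds go, whether a different kind of group on this carbon, such as an amine, a carboxylic acid or a longer chain, would move the half-life beyond the scatter remains open. Also open, from the compounds shown here alone, is whether methyl would behave the same way in place of the other fluoro group of compound 1.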